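Inserting a methylene between nitrogen and pyridine ring

The compounds below may be only part of what the source reports. "The series", "measured", "known", "first", "only" and "open" are said of these compounds alone.

Measured so far:
Compound 1 `CN(C(=S)SCc1ccc(C(=O)Nc2ccccc2N)cc1)c1cccnc1`: 87.7%
Compound 2 `Nc1ccccc1NC(=O)c1ccc(CSC(=S)N2CCN(Cc3cccnc3)CC2)cc1`: 89.2%

Both compounds were tested in a functional assay on A-375 cells (Homo sapiens) for antiproliferative activity, read by CCK-8 assay, with a stated time of 72 h, tested at 8 uM; a lower number here means a weaker effect, a higher number a stronger effect of the compound at the concentration tested. Compound 1 gives 87.7% and compound 2 gives 89.2%; the gap between them lies within the usual scatter of this measurement, so on the numbers shown compound 1 sits alongside compound 2 rather than apart from it, and neither can be called stronger.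

Compound 3 `CN(Cc1cccnc1)C(=S)SCc1ccc(C(=O)Nc2ccccc2N)cc1` has not yet been measured. It keeps the shared core of compound 1 and changes one group: (pyridin-3-yl)methyl in place of pyridin-3-yl on an amide-type nitrogen. In plain terms, the ring that was attached directly to the nitrogen is now held one saturated carbon further away.

Going by the values given here, no step between two measured compounds matches this change, so there is no direct guide to its size. Compound 2, which also carries a (pyridin-3-yl)methyl group, gives a value close to compound 1. Given that, the step from compound 1 to compound 3 is expected to be small, no larger than the scatter, with no clear direction: a number 0.7 percentage points lower from compound 1 to compound 3 (within the scatter). Compound 3 is therefore estimated at 87%, with a likely range from 76% to 95%.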

Compound 3, a percentage reported as inhibition, at one concentration (the size of the read-out at that concentration, not a potency): 83.8%
Beside the measured number, compound 3's estimate is 3.2 percentage points above it; low and high end bracket the measured number.
By their numbers in this assay, from the lowest: compounds 3, 1 and 2 (each within the scatter of the next).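

In this assay, holding the pyridine ring one saturated carbon further from the amide-type nitrogen gives a number 3.9 percentage points lower from compound 1 to compound 3 (within the scatter). This is the only direct measure of the change so far, and it shows that this read-out cannot tell (pyridin-3-yl)methyl from pyridin-3-yl at this position. No measurement shown bears on why the step has this size, and a difference within the scatter gives little to explain.

The compounds shown leave open whether a longer chain, such as 2-(pyridin-3-yl)ethyl, or a phenyl ring in place of the pyridine ring, would keep the read-out in the same range on this nitrogen. They also leave open whether compound 1 and compound 3 would separate in a true measure of potency, since a read-out at one concentration gives the size of the effect at that concentration only.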